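A few compounds are considered here, and "the series" means these few. Any claim that something is new, unique, unknown or untested is made for them only; others in the source may bear on it.

Working notes on the series. The shared core is carried by compound 2 `Nc1nc(N/N=C/c2ccc3ncccc3c2)nc2c1ncn2[C@@H]1O[C@H](CO)[C@@H](O)[C@H]1O`, compound 1 `N#Cc1ccc(/C=N/Nc2nc(N)c3ncn([C@@H]4O[C@H](CO)[C@@H](O)[C@H]4O)c3n2)cc1` and compound 3 `Nc1nc(N/N=C/c2cccnc2Cl)nc2c1ncn2[C@@H]1O[C@H](CO)[C@@H](O)[C@H]1O`, which differ only in the aryl group on the carbon with a double bond to nitrogen. In an assay on CHO-K1 cells for displacement of a labelled ligand from adenosine receptor A1 (Homo sapiens), read by scintillation counting, with a stated time of 60 min (on this read-out lower numbers stand for stronger inhibition and higher numbers for weaker inhibition), compound 2 gives 9.8 nM, the highest of the three numbers; compound 1 gives 4.1 nM and compound 3 gives 4.6 nM. The step of a 2.4-fold higher number from compound 1 to compound 2 (0.38 log units; beyond the scatter) and the step of a 2.1-fold lower number from compound 2 to compound 3 (0.33 log units; beyond the scatter) set compound 2 apart from both, whereas a 1.1-fold higher number from compound 1 to compound 3 (0.05 log units; within the scatter) stays within the scatter.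

Compound 4 `Nc1nc(N/N=C/c2ccc(C(F)(F)F)cc2)nc2c1ncn2[C@@H]1O[C@H](CO)[C@@H](O)[C@H]1O` has not yet been measured. Its change from compound 2 is 4-(trifluoromethyl)phenyl in place of quinolin-6-yl on a carbon with a double bond to nitrogen. For the measured compounds named here, two measured steps bear on it: leaving quinolin-6-yl for 2-chloropyridin-3-yl gave a 2.1-fold lower number from compound 2 to compound 3 (0.33 log units; beyond the scatter), and a 2.4-fold higher number from compound 1 to compound 2 (0.38 log units; beyond the scatter) shows the move the other way, from 4-cyanophenyl onto quinolin-6-yl. Both point to a modest lower number in this assay once quinolin-6-yl is replaced, so compound 4 is expected to sit near compound 1 and compound 3. For compound 4 the estimate is 5 nM, with a range of 2 nM to 13 nM. That corresponds to an expected step of a 2.0-fold lower number from compound 2 to compound 4 (0.29 log units; within the scatter).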

Compound 4, inhibition constant: 37 nM
Estimate against measurement, compound 4: 7.4-fold (0.87 log units) below; measured number above the stated range.
By their numbers in this assay, from the lowest: compounds 1 and 3 (each within the scatter of the next); then compound 2; then compound 4.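

The position on the carbon with a double bond to nitrogen does not treat all aryl groups alike: with a 3.8-fold higher number from compound 2 to compound 4 (0.58 log units; beyond the scatter), 4-(trifluoromethyl)phenyl is the only replacement of quinolin-6-yl shown that raises the number, so quinolin-6-yl no longer marks the weak end of the series. The change of trifluoromethyl in place of cyano on an aromatic carbon alone gives a 9.0-fold higher number from compound 1 to compound 4 (0.96 log units; beyond the scatter), and an 8.0-fold higher number from compound 3 to compound 4 (0.91 log units; beyond the scatter) separates compound 4 from 2-chloropyridin-3-yl as well, so a phenyl ring at this place can lie on either side of quinolin-6-yl depending on what it carries. No measurement at hand speaks to why compound 4 stands apart.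

The compounds shown leave open how an unsubstituted phenyl would read at this place, and so whether trifluoromethyl or cyano is the group that moves the number. Also open, from the compounds shown here alone, is where a methoxy group, an amine or a carboxylic acid on the same phenyl would fall relative to compound 1 and compound 4.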